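The source may report more compounds than this note shows. Statements on the series, on what has been measured and on what is new or still open speak of the compounds shown alone.

In a functional assay on HeLa cells (Homo sapiens) for antiproliferative activity, read by MTT assay, with a stated time of 48 h (on this read-out lower numbers stand for stronger inhibition of growth and higher numbers for weaker inhibition of growth), compound 1, with the structure `COc1ccc(/C=C2\Cc3c(cc(OC)c(OC)c3OC)C2=O)cc1O`, gives 172 nM. Compound 2, with the structure `COc1ccc(/C=C2\Cc3c(cc(OC)c(OC)c3OC)C2=O)cc1OC`, carries methyl in place of hydrogen on an oxygen on an aromatic ring and in this assay gives 8560 nM; this single change brings a 50-fold higher number from compound 1 to compound 2 (1.70 log units; beyond the scatter). Compound 3 has the structure `COc1cc2c(cc1O)C(=O)/C(=C/c1cc(OC)c(OC)c(OC)c1)C2`. For compound 3 this assay reports only a limit, > 10000 nM, which is the limit of > 10000 nM in this assay, at which 1 of the 3 values shown sits. Compound 3 and compound 1 are built from the same atoms joined differently, and the difference between the two cores is not broken down here. Compound 4, with the structure `COc1cc2c(cc1OC)C(=O)/C(=C/c1cc(OC)c(OC)c(OC)c1)C2`, is not yet measured; it differs from compound 3 by methyl in place of hydrogen on an oxygen on an aromatic ring, the same change that separates compound 2 from compound 1. Since the same change on compound 1 gave a 50-fold higher number from compound 1 to compound 2 (1.70 log units; beyond the scatter) and compound 3 already stands only at a limit, the expected step from compound 3 to compound 4 is a step that the limit leaves unreadable from compound 3 to compound 4, most likely again ending at a limit rather than a number. Compound 4 is therefore estimated at 40000 nM, somewhere between 9000 nM and 300000 nM.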

Compound 4, concentration for 50% growth inhibition: > 10000 nM
Compound 4: a limit, no number; the forecaster's own chance of this, stated with the estimate: 90%; the middle value does not contradict the limit.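

In this assay compound 4 gives > 10000 nM, which is a limit and not a number. Compound 3 also stands only at a limit, so no step from compound 3 to compound 4 can be read: the limit of > 10000 nM in this assay, at which 2 of the 4 values shown sit.

The compounds shown leave open whether methyl in place of hydrogen on an oxygen on an aromatic ring changes growth inhibition at all on the core shared by compound 3 and compound 4.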